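The compounds below may be only part of what the source reports. "The series", "measured", "known", "first", "only" and "open" are said of these compounds alone.

In a functional assay on cells (leukaemia cell line, Homo sapiens) for inhibition, read by sulforhodamine B assay, with a stated time of 48 h (a higher number here means that more compound is tolerated, a lower number that less compound is tolerated), three compounds sharing one core have been measured. Compound 1 `O=S(=O)(Nc1ccc(Cl)c(Cl)c1)c1ccc(-c2cnc(C3CC3)o2)cc1` gives > 100000 nM, which is a limit and not a number. Compound 2 `O=S(=O)(Nc1ccc(Br)c(Cl)c1)c1ccc(-c2cnc(C3CC3)o2)cc1` gives > 100000 nM, again a limit. Compound 3 `O=S(=O)(Nc1ccc(F)cc1F)c1ccc(-c2cnc(C3CC3)o2)cc1` gives > 100000 nM, so it too stands only at a limit.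

The next compound, compound 4 `O=S(=O)(Nc1cc(Cl)ccc1Cl)c1ccc(-c2cnc(C3CC3)o2)cc1`, differs from compound 3 on the sulfonamide nitrogen: 2,5-dichlorophenyl in place of 2,4-difluorophenyl on a sulfonamide nitrogen. The measured steps that bear on this change are a step that the two limits leave unreadable from compound 1 to compound 3 and a step that the two limits leave unreadable from compound 2 to compound 3, both exchanges of the group at that same place, along with a step that the two limits leave unreadable from compound 1 to compound 2. Going by the values given here, none of them has a readable size, and the series so far shows (the limit of > 100000 nM in this assay, at which 3 of the 3 values shown sit). Compound 1 also carries a dichlorophenyl group on that nitrogen and gives the limit > 100000 nM, so no step beyond the scatter is expected. The expected step is a number no higher from compound 3 to compound 4 (the limit leaves the size open). For compound 4 the estimate is 100000 nM, with an expected range of 40000 nM to 200000 nM, and a report of only a limit is likely.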

Compound 4, concentration lethal to 50% of the cells: > 100000 nM
Compound 4 ended at the assay's limit (the forecaster's own chance of this, stated with the estimate: 85%); the middle value sits exactly at the limit.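

Compound 4 stands only at a limit, as do compound 1, compound 2 and compound 3, so none of the new steps to compound 4 in this assay can be read. The compounds shown leave open whether the group on the sulfonamide nitrogen alters the read-out at all, for the series offers only one reading: the limit of > 100000 nM in this assay, at which 4 of the 4 values shown sit.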